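This account rests on a few compounds, and the source may have more. Where it says the series, first, only, none or still open, it means among the compounds named here.

Working notes on the series.

Compound 1 `N#CC1=C(N)N(c2ccc(S(N)(=O)=O)cc2)C2=C(CCCC2)C1c1ccc(O)cc1` and compound 2 `COc1ccc(C2C(C#N)=C(N)N(c3ccc(S(N)(=O)=O)cc3)C3=C2CCCC3)cc1` share a core and differ only as methyl in place of hydrogen on an oxygen on an aromatic ring. In a functional assay on Ehrlich cells (Mus musculus) for cytotoxicity, read by trypan blue exclusion, with a stated time of 2 h, tested at 100 ug/mL (on this read-out lower numbers stand for a weaker effect and higher numbers for a stronger effect at the one concentration tested), compound 1 gives 100%, and in this assay compound 2 gives 100%; the step of no change at the digits printed from compound 1 to compound 2 (within the scatter) is therefore flat. Compound 3 `N#CC1=C(N)N(c2ccc(S(N)(=O)=O)cc2)C2=C(CCCC2)C1c1c(O)ccc2ccccc12` carries a different group on the saturated ring carbon, the difference being (2-hydroxynaphthalen-1-yl in place of 4-hydroxyphenyl on a saturated ring carbon). In this assay compound 3 gives 50%; the step of a number 50 percentage points lower from compound 1 to compound 3 (beyond the scatter) and the step of a number 50 percentage points lower from compound 2 to compound 3 (beyond the scatter) are both large, and compound 3 stands lowest of the three measured.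

Compound 4 `COc1ccc2ccccc2c1C1C(C#N)=C(N)N(c2ccc(S(N)(=O)=O)cc2)C2=C1CCCC2` is not yet measured. Among the compounds with values here, it differs from compound 3 as methyl in place of hydrogen on an oxygen on an aromatic ring, which is the same change as the one from compound 1 to compound 2: the place lines read alike, on an oxygen on an aromatic ring whose other neighbours are aromatic carbon. What differs is the core, as set out above under the difference between compound 1 and compound 3. The one measured instance of this methylation sits at the top of the scale, where a gain could not have shown, so it is only weak evidence that the methyl leaves the read-out unchanged.

The step from compound 3 to compound 4 is expected to be small, no change at the digits printed from compound 3 to compound 4 (within the scatter), resting on the flat step no change at the digits printed from compound 1 to compound 2 (within the scatter) and starting from the measured value of compound 3. Compound 4 is expected to give about 50% in this assay, estimated to lie between 20% and 85%, because compound 3 gives 50% and the precedent shows no shift.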

Compound 4, a percentage reported as activity, at one concentration (the size of the read-out at that concentration, not a potency): 50%
Estimate against measurement, compound 4: no gap at the digits printed; the range from low to high includes it.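

In this assay, methyl in place of hydrogen on an oxygen on an aromatic ring now shows no change at the digits printed from compound 3 to compound 4 (within the scatter), and this reading starts from the middle of the scale, where a move in either direction could have shown, unlike the earlier pair at the top of the scale. Set beside the earlier instance, the change reads alike on the two cores: the same change on two cores in this assay, no change at the digits printed (within the scatter) from compound 1 to compound 2 and no change at the digits printed (within the scatter) from compound 3 to compound 4, 0 percentage points apart, within the scatter of two such steps. This shows that hydroxy to methoxy is flat on these two cores at the one concentration tested, but it gives no potency, does not show that the flat step would hold on a third core, and does not explain the lower read-out seen with a number 50 percentage points lower from compound 1 to compound 3 (beyond the scatter).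

The compounds shown leave open whether a larger group on that oxygen, such as an ethyl or a longer chain, or an amine or a carboxylic acid in place of the hydroxy, would read the same. Also open, as far as these compounds go, is what a plain phenyl or a naphthalen-1-yl without any oxygen on it would give on the saturated ring carbon.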